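From phenyl to pyridin-4-yl on a shared core

The source may report more compounds than this note shows. Statements on the series, on what has been measured and on what is new or still open speak of the compounds shown alone.

Among the compounds with values here, in a functional assay on L1210 cells (Mus musculus) for antiproliferative activity (on this read-out higher numbers stand for weaker inhibition and lower numbers for stronger inhibition), compound 3 `COc1cc(C(=O)c2sc(-c3ccccc3)cc2N)cc(OC)c1OC` gives 11 nM, the lowest number so far. Compound 1 `COc1ccc(-c2cc(N)c(C(=O)c3cc(OC)c(OC)c(OC)c3)s2)cc1OC` gives 40 nM, and compound 2 `COc1cc(C(=O)c2sc(-c3ccc(Cl)cc3)cc2N)cc(OC)c1OC` gives 93 nM. Compound 4 `COc1cc(C(=O)c2sc(-c3ccncc3)cc2N)cc(OC)c1OC` has not yet been measured. It carries pyridin-4-yl in place of phenyl (pyridin-4-yl in place of phenyl on an aromatic carbon).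

Within the data shown here, two measured steps concern this same place, and both end at the plain phenyl: a 3.6-fold lower number from compound 1 to compound 3 (0.56 log units; beyond the scatter), and an 8.5-fold lower number from compound 2 to compound 3 (0.93 log units; beyond the scatter). In these three compounds, both other rings gave higher numbers than phenyl. Among the measured compounds shown here, no measured compound carries pyridin-4-yl, which leaves this guide loose. In this assay, a modest upward step is therefore expected: a 4.1-fold higher number from compound 3 to compound 4 (0.61 log units; beyond the scatter). For compound 4 the estimate is 45 nM, with an expected range from 12 nM to 170 nM.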

Compound 4, half-maximal inhibitory concentration: 1810 nM
Compound 4: middle estimate off by 40-fold (1.60 log units), on the low side; the measured number lies above the stated range.
By their numbers in this assay, from the lowest: compound 3; then compound 1; then compound 2; then compound 4.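

In this assay, replacing one ring carbon of phenyl with nitrogen gives a 160-fold higher number from compound 3 to compound 4 (2.22 log units; beyond the scatter), a large step where the earlier changes at this position were only modest. Pyridin-4-yl also does worse than both substituted rings, with a 19-fold higher number from compound 2 to compound 4 (1.29 log units; beyond the scatter) and a 45-fold higher number from compound 1 to compound 4 (1.66 log units; beyond the scatter). This position therefore tolerates 4-chlorophenyl and 3,4-dimethoxyphenyl far better than this single atom change.

Nothing available explains the loss. As far as these compounds go, it remains open whether pyridin-3-yl, with its nitrogen elsewhere in the ring, or 4-aminophenyl would give numbers closer to compound 3 or compound 4.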